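Swapping the Aryl Group on the Thioether Linker

The source may report more compounds than this note shows. Statements on the series, on what has been measured and on what is new or still open speak of the compounds shown alone.

Measured so far:
compound 1, `Nc1ccccc1NC(=O)/C=C/c1ccc(CSc2cccc(F)c2)cc1`: 2.25%
compound 2, `Nc1ccccc1NC(=O)/C=C/c1ccc(CSc2cccc3ccccc23)cc1`: 20.6%

Both compounds share one core and differ only in the group attached to the sulfur. In a functional assay on HeLa cells (Homo sapiens) for inhibition, read by CCK-8 assay, with a stated time of 72 h, tested at 2 uM (on this read-out lower numbers stand for less inhibition of growth and higher numbers for more inhibition of growth at the one concentration tested), compound 2 gives 20.6% and stands highest of the two numbers, its nearest neighbour being compound 1 with 2.25%. Within the data shown here, the single step known, a number 18.4 percentage points higher from compound 1 to compound 2 (beyond the scatter), shows that replacing 3-fluorophenyl by naphthalen-1-yl on the sulfur raised growth inhibition beyond the scatter.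

Compound 3, `Nc1ccccc1NC(=O)/C=C/c1ccc(CSCCc2ccccc2)cc1`, is not yet measured. It differs from compound 2 as follows: phenethyl in place of naphthalen-1-yl on a sulfur. Among the measured compounds shown here, the one step known bears on it only loosely: it concerns the same sulfur position, and there the larger two-ring group gave the higher number, while the single-ring group of compound 1 gave the lower one. Phenethyl is again a single-ring group, so a drop in this assay toward the region of compound 1 is expected, though the direction is uncertain. The expected change for compound 3 is a number 12.6 percentage points lower from compound 2 to compound 3 (beyond the scatter), and its estimated value is 8% with a range from 0% to 25%.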

Compound 3, percent growth inhibition at one concentration: 0.19%
Beside the measured number, compound 3's estimate is 7.8 percentage points above it, and the stated range covers the measured number.
By their numbers in this assay, from the lowest: compounds 3 and 1 (each within the scatter of the next); then compound 2.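

In this assay, phenethyl in place of naphthalen-1-yl on the sulfur gives a number 20.4 percentage points lower from compound 2 to compound 3 (beyond the scatter), so the higher number of compound 2 does not survive this exchange for a group with one six-membered aromatic ring. Phenethyl in place of 3-fluorophenyl gives a number 2.1 percentage points lower from compound 1 to compound 3 (within the scatter), which means that these two single-ring groups cannot be told apart in this read-out, and among the three groups shown only naphthalen-1-yl stands apart. No measurement at hand explains why the naphthalen-1-yl compound gives the higher number.

The compounds shown leave open whether the higher number belongs to two fused aromatic rings in general or to naphthalen-1-yl in particular, a question that a naphthalen-2-yl or a biphenyl group on the same sulfur could help to answer. Among these compounds, they also leave open how a group carrying an amine or a carboxylic acid would behave on this sulfur, and how the differences seen at the single tested concentration would look across a range of concentrations.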